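Replacing the Nitro Group in a Trifluoromethyl Indazole Series

The compounds below may be only part of what the source reports. "The series", "measured", "known", "first", "only" and "open" are said of these compounds alone.

Compound 2 `O=[N+]([O-])c1cccc(CNc2cc(C(F)(F)F)cc3[nH]ncc23)c1` stands lowest of the two measured compounds in an assay for inhibition of Indoleamine 2,3-dioxygenase 1 (Homo sapiens), with stated times of 10 min and 60 min, tested at 10 uM (a lower number here means a weaker effect, a higher number a stronger effect of the compound at the concentration tested), giving 45%. Going by the values given here, compound 1 `O=[N+]([O-])c1cccc(CNc2cc(Br)cc3[nH]ncc23)c1` gives 72% in this assay, and the only measured step, a number 27 percentage points lower from compound 1 to compound 2 (beyond the scatter), concerns trifluoromethyl in place of bromo on an aromatic carbon and touches nothing of the change considered here. Compound 3 `CNC(=O)c1cccc(CNc2cc(C(F)(F)F)cc3[nH]ncc23)c1` differs from compound 2 as follows: methylcarbamoyl in place of nitro on an aromatic carbon. Among the compounds with values here, no measured step involves methylcarbamoyl in place of nitro on an aromatic carbon, so the expected size of this step rests on no direct precedent and carries wide uncertainty. Compound 3 is therefore expected to give 30% in this assay, within a range of 5% to 65%. The step of a number 15 percentage points lower from compound 2 to compound 3 (beyond the scatter) is estimated as a modest move downward, with a real chance that it lies within the scatter.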

Compound 3, a percentage reported as inhibition, at one concentration (the size of the read-out at that concentration, not a potency): 33%
Estimate against measurement, compound 3: 3 percentage points below; low and high end bracket the measured number.
By their numbers in this assay, from the lowest: compound 3; then compound 2; then compound 1.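

Going by these compounds alone, the replacement of nitro by methylcarbamoyl on this aromatic carbon gives a number 12 percentage points lower from compound 2 to compound 3 (beyond the scatter) in this assay, the first measured change at this place on the ring. It shows that the read-out responds to the group held here, as it does to the exchange of bromo for trifluoromethyl elsewhere on the molecule, and that nitro is not indispensable: compound 3 still gives 33% at the concentration tested. Nothing available explains why the number falls with this change.

Going by these compounds, whether a nitrile, a carboxylic acid or an unsubstituted carboxamide at this place would stay closer to compound 2 remains open. Also open, on these data alone, is whether methylcarbamoyl would cost a similar amount on the bromo compound, compound 1.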